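Bromo for Fluoro on a Longer-Chain Core

The compounds below may be only part of what the source reports. "The series", "measured", "known", "first", "only" and "open" are said of these compounds alone.

Compound 1 `CCN1CCN(c2ccc(S(=O)(=O)Oc3cccc(F)c3)cc2)C1=O` and compound 2 `CCN1CCN(c2ccc(S(=O)(=O)Oc3cccc(Br)c3)cc2)C1=O` share one core and differ at a single aromatic position: bromo in place of fluoro on an aromatic carbon. In a functional assay on M21 cells (Homo sapiens) for antiproliferative activity, read by sulforhodamine B assay, with a stated time of 48 h (on this read-out lower numbers stand for stronger inhibition and higher numbers for weaker inhibition), compound 1 gives 11000 nM. In this assay compound 2 gives 3400 nM. The swap therefore brought a 3.2-fold lower number from compound 1 to compound 2 (0.51 log units; beyond the scatter), a modest gain.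

Compound 3 `CCCCN1CCN(c2ccc(S(=O)(=O)Oc3cccc(F)c3)cc2)C1=O` carries a different core, which differs from the core of compound 1 as follows: ethyl in place of hydrogen on a saturated chain carbon, two bonds along the chain from an amide-type nitrogen in a ring. In this assay compound 3 reaches only a limit of the assay, > 100000 nM. The lengthened chain thus gave an at least 9.0-fold higher number from compound 1 to compound 3 (0.95 log units; beyond the scatter), and the step can only be bounded because of the limit of > 100000 nM in this assay, at which 1 of the 3 values shown sits.

Compound 4 `CCCCN1CCN(c2ccc(S(=O)(=O)Oc3cccc(Br)c3)cc2)C1=O` applies the same halogen change to the core of compound 3: bromo in place of fluoro on an aromatic carbon. The place of the change is the same in both pairs, so a step of about the same size as a 3.2-fold lower number from compound 1 to compound 2 (0.51 log units; beyond the scatter) is expected. For compound 4 the expected step is an at least 2.5-fold lower number from compound 3 to compound 4 (0.39 log units; beyond the scatter). Since compound 3 itself is only a limit, the starting point is uncertain, and compound 4 may again fall at a limit. Compound 4 is estimated at 40000 nM, most likely between 10000 nM and 150000 nM.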

Compound 4, half-maximal inhibitory concentration: 35000 nM
Estimate against measurement, compound 4: 1.1-fold (0.06 log units) above; low and high end bracket the measured number.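

In this assay, bromo in place of fluoro brought an at least 2.8-fold lower number from compound 3 to compound 4 (0.45 log units; beyond the scatter), which runs the same way as on the core of compound 1: the same change on two cores in this assay, a 3.2-fold lower number (0.51 log units; beyond the scatter) from compound 1 to compound 2 and an at least 2.8-fold lower number (0.45 log units; beyond the scatter) from compound 3 to compound 4; the limit leaves it open whether they differ. Lengthening the chain on the bromo compounds brought a 10-fold higher number from compound 2 to compound 4 (1.01 log units; beyond the scatter), again the same way as on the fluoro compounds: the same change on two cores in this assay, an at least 9.0-fold higher number (0.95 log units; beyond the scatter) from compound 1 to compound 3 and a 10-fold higher number (1.01 log units; beyond the scatter) from compound 2 to compound 4; the limit leaves it open whether they differ. Compound 3 stands only at a limit of the assay, > 100000 nM, so these four compounds show that both changes carry from one core to the other in direction, but not that they carry with the same size.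

On these data alone, whether chloro or methoxy in the same place on the ring would also give a lower number than fluoro remains open, since only two substituents are compared here. As far as these compounds go, it is also open how a propyl chain or a longer chain would read, and whether the loss seen on lengthening from ethyl continues, levels off or reverses.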